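The source may hold more compounds than are shown below. What is called first, only, known or untested is meant among the compounds shown, and "the series" means these compounds.

Of the compounds shown here, two built on one shared core have been measured so far. Compound 1 `COc1ccc(F)cc1CNCCCNc1ccnc2cc(-c3cccc4ccccc34)ccc12` carries a naphthalen-1-yl group, and in an ADME assay on HepG2 cells (Homo sapiens) for cytotoxicity, read by luminescence, CellTiter-Glo and ATP content, with a stated time of 72 h (on this read-out lower numbers stand for an effect already at smaller amounts and higher numbers for an effect only at larger amounts of compound), compound 1 gives 16000 nM. Compound 2 `COc1ccc(F)cc1CNCCCNc1ccnc2cc(-c3ccc(C(C)(C)C)cc3)ccc12` carries a 4-(tert-butyl)phenyl group instead; in this assay compound 2 gives 620 nM. Within the data shown here, compound 2 thus holds the lower of the two numbers, and the one recorded step, a 26-fold lower number from compound 1 to compound 2 (1.41 log units; beyond the scatter), shows how strongly that single swap moved the read-out. Compound 3 `COc1ccc(F)cc1CNCCCNc1ccnc2cc(CC3CCCCC3)ccc12` differs from compound 2 as follows: cyclohexylmethyl in place of 4-(tert-butyl)phenyl on an aromatic carbon. Among the measured compounds shown here, only the step from compound 1 to compound 2 bears on this, and it exchanged one aromatic group for another, whereas here an aromatic ring gives way to a non-aromatic one, a kind of change no measured step covers. The direction is therefore uncertain, and a moderate step upward, a 2.4-fold higher number from compound 2 to compound 3 (0.38 log units; beyond the scatter), is expected. Compound 3 is estimated to give 1500 nM in this assay, within a range from 400 nM to 6000 nM.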

Compound 3, half-maximal effective concentration: 1830 nM
Compound 3: middle estimate off by 1.2-fold (0.09 log units), on the low side, within the range that was stated.
By their numbers in this assay, from the lowest: compound 2; then compound 3; then compound 1.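

The new compound shows that an aromatic ring at this position does not by itself set the read-out in this assay. The non-aromatic cyclohexylmethyl group falls between the two aromatic groups: swapping in cyclohexylmethyl for 4-(tert-butyl)phenyl gives a smaller change (a 3.0-fold higher number from compound 2 to compound 3 (0.47 log units; beyond the scatter)) than swapping it in for naphthalen-1-yl (an 8.7-fold lower number from compound 1 to compound 3 (0.94 log units; beyond the scatter)), which moves the number the other way. Nothing measured here explains this order of the three groups.

The compounds shown leave open how a group carrying an amine or a carboxylic acid, or a plain longer alkyl chain, would behave on this aromatic carbon. They also leave open whether the same order would hold if the rest of the shared core were changed.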